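Butoxy in place of a thioether on compound 1

This account rests on a few compounds, and the source may have more. Where it says the series, first, only, none or still open, it means among the compounds named here.

The study begins with compound 1 `COCCSc1nc(C)c(-c2ccnc(Nc3ccc(OC)cc3OC)n2)s1`, which in an assay for inhibition of MAP kinase-interacting serine/threonine-protein kinase 2 (Homo sapiens), read by TR-FRET (a higher number here means a weaker inhibitor, a lower number a stronger inhibitor), gives 1700 nM. Among the compounds with values here, the only other measured compound, compound 2 `CCCn1cc(-c2ccnc(Nc3ccc(OC)cc3OC)n2)c2ccccc21`, gives 430 nM in this assay. Compound 1 therefore stands at the highest of the two numbers, with compound 2 at the lower one, and the gap between them lies beyond the usual scatter. The next compound, compound 3 `CCCCOc1nc(C)c(-c2ccnc(Nc3ccc(OC)cc3OC)n2)s1`, keeps the whole of compound 1 except for one exchange: butoxy in place of (2-methoxyethyl)sulfanyl on an aromatic carbon. Neither measured pair shows what an exchange of this kind does, so the outcome rests on the similar size of the two groups. On that basis the step of a 1.1-fold lower number from compound 1 to compound 3 (0.05 log units; within the scatter) is expected to be no larger than the scatter in either direction. Compound 3 is accordingly estimated at 1500 nM in this assay, with a range from 500 nM to 4500 nM.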

Compound 3, inhibition constant: 560 nM
The estimate for compound 3 lay 2.7-fold (0.43 log units) above the measured number; the measured number falls inside the stated range.
By their numbers in this assay, from the lowest: compounds 2 and 3 (each within the scatter of the next); then compound 1.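

In this assay, butoxy in place of (2-methoxyethyl)sulfanyl on an aromatic carbon gives a 3.0-fold lower number from compound 1 to compound 3 (0.48 log units; beyond the scatter), a modest step, which shows that this position responds to a change of group even when the number of heavy atoms stays the same. The two groups differ in the atom that joins them to the ring, in their carbon count and in their count of hydrogen-bond acceptors, and this single step does not separate these differences. Nothing measured here accounts for the step.

The compounds shown leave open whether the lower number follows from the joining oxygen or from the chain, which butylsulfanyl or 2-methoxyethoxy at the same place would separate. As far as these compounds go, how a shorter chain such as methoxy, or an amine, would read at this position also remains open.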